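Bromo-to-nitro swap on the phenacyl arm: a cytotoxicity note

A few compounds are considered here, and "the series" means these few. Any claim that something is new, unique, unknown or untested is made for them only; others in the source may bear on it.

Measured so far:
- compound 1, `O=C(CSc1nnc(N2CCN(c3cc4c(cc3F)c(=O)c(C(=O)O)cn4C3CC3)CC2)s1)c1ccc([N+](=O)[O-])cc1`: > 6.1 ug/mL
- compound 2, `CCn1cc(C(=O)O)c(=O)c2cc(F)c(N3CCN(c4nnc(SCC(=O)c5ccc(Br)cc5)s4)CC3)cc21`: 5 ug/mL

Among the compounds with values here, in an ADME assay on Vero cells (Chlorocebus sabaeus) for inhibition, read by MTT assay, with a stated time of 96 h (a higher number here means a weaker inhibitor, a lower number a stronger inhibitor), compound 2 gives 5 ug/mL, the only numerical value so far. For compound 1 the result in this assay is a limit, > 6.1 ug/mL, and not a number. Within the data shown here, compound 2 therefore stands alone as a measured point; the other entry is an assay limit, see (the limit of > 6.1 ug/mL in this assay, at which 1 of the 2 values shown sits), so no measured step between two numbers is available.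

Compound 3, `CCn1cc(C(=O)O)c(=O)c2cc(F)c(N3CCN(c4nnc(SCC(=O)c5ccc([N+](=O)[O-])cc5)s4)CC3)cc21`, is still to be tested in this assay. It differs from compound 2 in one place: nitro in place of bromo on an aromatic carbon. Among the measured compounds shown here, no step between measured compounds is on record, so the size and direction of this change in this assay cannot be read from data. Compound 1 also carries the nitro group and sits at a limit, but it differs from compound 3 elsewhere as well, so it carries no direct lesson.

Compound 3 is expected to come out at about 7 ug/mL, within 3 ug/mL to 15 ug/mL. The expected step of a 1.4-fold higher number from compound 2 to compound 3 (0.15 log units; within the scatter) is small, toward weaker inhibition if at all, and within the usual scatter.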

Compound 3, half-maximal inhibitory concentration: > 10.2 ug/mL
Compound 3 was reported as a limit; the forecaster's own chance of this, stated with the estimate: 40%; middle value at least 1.4-fold (0.16 log units) from the limit.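

In this assay the change from 4-bromophenyl to 4-nitrophenyl, para to a large group, now has its first readable step between two compounds that differ in this one place: an at least 2.0-fold higher number from compound 2 to compound 3 (0.30 log units; that floor lies within the scatter). For compound 3 the result is a limit and not a number: the limit of > 10.2 ug/mL in this assay, at which 1 of the 3 values shown sits. The pair therefore fixes only a floor for this step, and that floor does not by itself separate the two compounds beyond the scatter, though nothing on record so far points toward stronger inhibition with nitro in place of bromo on this aromatic carbon.

On these data alone, the step from compound 1 to compound 3, ethyl in place of cyclopropyl on an aromatic nitrogen, cannot be read, so the part played by that group in this assay stays unknown. Also open, as far as these compounds go, are the true size of the step from bromo to nitro and how an amino group or a methoxy group at the same place on the phenyl ring would read against compound 2.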